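Swapping cyclopropylmethyl for propyl on the aryl amine

The source may report more compounds than this note shows. Statements on the series, on what has been measured and on what is new or still open speak of the compounds shown alone.

Of the compounds shown here, three sharing one core have been measured in an assay for inhibition of leukotriene C4 synthase (Homo sapiens), read by LC-MS, with stated times of 15 min and 30 min; on this read-out lower numbers stand for stronger inhibition and higher numbers for weaker inhibition. Compound 1 `COc1cc(N(CC2CC2)c2ccc(Cl)c(Cl)c2)cnc1C(=O)[C@H]1C[C@@H]1C(=O)O` gives 4.94 nM. Compound 2 `COc1cc(N(CC2CC2)c2ccccc2)cnc1C(=O)[C@H]1C[C@@H]1C(=O)O` gives 158 nM, and compound 3 `COc1cc(N(CC2CC2)c2cccc(C(F)(F)F)c2)cnc1C(=O)[C@H]1C[C@@H]1C(=O)O` gives 6.42 nM. The steps among them all lie on the aryl group attached to the nitrogen: a 32-fold higher number from compound 1 to compound 2 (1.50 log units; beyond the scatter), a 1.3-fold higher number from compound 1 to compound 3 (0.11 log units; within the scatter), and a 25-fold lower number from compound 2 to compound 3 (1.39 log units; beyond the scatter). Compound 3 thus stands second highest of the three numbers, close to compound 1 within the scatter and far from compound 2 beyond it.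

Compound 4 `CCCN(c1cccc(C(F)(F)F)c1)c1cnc(C(=O)[C@H]2C[C@@H]2C(=O)O)c(OC)c1` differs from compound 3 at a different place: ethyl in place of cyclopropyl on a saturated chain carbon bound to a nitrogen on an aromatic ring. Among the measured compounds shown here, none of the measured steps touches this chain on the nitrogen, since all of them vary the aryl ring, so no measured step bears directly on the change. For the measured compounds named here, the only guidance is that compound 3 sits near the low end of the three numbers, and the two large steps concern the aryl group alone. The step is therefore expected to be small, a 1.2-fold higher number from compound 3 to compound 4 (0.10 log units; within the scatter), with no direction preferred beyond the scatter. Compound 4 is estimated to give 8 nM in this assay, with a range from 2.5 nM to 25 nM.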

Compound 4, half-maximal inhibitory concentration: 7.9 nM
The estimate for compound 4 lay 1.0-fold (0.01 log units) above the measured number; the range from low to high includes it.
By their numbers in this assay, from the lowest: compounds 1, 3 and 4 (each within the scatter of the next); then compound 2.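

In this assay, among the compounds shown here, the chain on the nitrogen changes for the first time, and the step is a 1.2-fold higher number from compound 3 to compound 4 (0.09 log units; within the scatter) within the scatter, so with the 3-(trifluoromethyl)phenyl group held fixed, cyclopropylmethyl and propyl cannot be told apart. For the compounds shown here, for this one pair, the three-membered ring of carbon is therefore not needed at this place to keep a number in the same range, whereas the earlier steps all concerned the aryl group on the nitrogen and included the large 25-fold lower number from compound 2 to compound 3 (1.39 log units; beyond the scatter) shift. Nothing given here explains why the two chains read alike.

The compounds shown leave open whether propyl and cyclopropylmethyl would also read alike with 3,4-dichlorophenyl or plain phenyl on the nitrogen, since this single pair carries only the 3-(trifluoromethyl)phenyl group. They also leave open how far this place tolerates other groups, such as a longer chain like butyl, a branched chain like isopropyl, or a chain ending in an amine or a carboxylic acid.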